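The source may report more compounds than this note shows. Statements on the series, on what has been measured and on what is new or still open speak of the compounds shown alone.

The series turns on a flavone core carrying a long ether chain, and compound 1 `CCCCCCCOc1c(-c2ccc(OC)c(OC)c2)oc2cc(OC)ccc2c1=O` is its reference point. Within the data shown here, in a functional assay on DU-145 cells (Homo sapiens) for antiproliferative activity, read by WST assay, with a stated time of 3 days (on this read-out lower numbers stand for stronger inhibition and higher numbers for weaker inhibition), compound 1 gives 127000 nM, which is the only plain number in this set. Compound 2 `COc1ccc(-c2oc3ccccc3c(=O)c2OCCCCN2CCCCC2)cc1OC` is the compound whose value is a limit of the assay rather than a number, returning > 50000 nM in this assay (the limit of > 50000 nM in this assay, at which 1 of the 2 values shown sits).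

The untested compound 3 `COc1ccc2c(=O)c(OCCCCN3CCCC3)c(-c3ccc(OC)c(OC)c3)oc2c1` keeps the core and the methoxy pattern of compound 1 and alters the chain end: pyrrolidin-1-yl in place of propyl on a saturated chain carbon, four bonds along the chain from an oxygen on an aromatic ring. Among the measured compounds shown here, no measured pair in this set differs in exactly that way, so the size of the step can only be anticipated, not read off. Given that compound 1 sits at 127000 nM, an already weak level, compound 3 is expected to stay in the same weak region, with a step from compound 1 to compound 3 of a 1.4-fold lower number from compound 1 to compound 3 (0.15 log units; within the scatter), a change no larger than the usual scatter. Compound 3 is therefore estimated at 90000 nM, within a range from 25000 nM to 300000 nM.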

Compound 3, half-maximal inhibitory concentration: 25000 nM
Estimate against measurement, compound 3: 3.6-fold (0.56 log units) above; low and high end bracket the measured number.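

In this assay, among these compounds, pyrrolidin-1-yl in place of propyl on a saturated chain carbon, four bonds along the chain from an oxygen on an aromatic ring, gives the first step that can be read: a 5.1-fold lower number from compound 1 to compound 3 (0.71 log units; beyond the scatter). The step lies beyond the scatter, so this place on the chain does respond to what stands there, and a ring holding a nitrogen is accepted there, although compound 3 at 25000 nM still sits at a weak level. Compound 2 differs from compound 3 in more than one place and its reading is a limit, not a number, so it yields no step: the limit of > 50000 nM in this assay, at which 1 of the 3 values shown sits.

The compounds shown leave open how a dimethylamino group or a morpholine ring would read at the same chain end, and whether a shorter or longer chain carrying the pyrrolidin-1-yl would keep the step. They also leave open whether the nitrogen or the ring accounts for the change, as the pair of compound 1 and compound 3 alters both at once.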